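Replacing a bromophenyl thiourea substituent with methyl: expected tolerance

This account rests on a few compounds, and the source may have more. Where it says the series, first, only, none or still open, it means among the compounds named here.

Compound 1 `Cc1ccccc1NC(=S)N/N=C1\C(=O)Nc2ccccc21` and compound 2 `O=C1Nc2ccccc2/C1=N/NC(=S)Nc1ccc(Br)cc1` share the same core and differ only on an amide-type nitrogen. In an ADME assay on RD cells (Homo sapiens) for cytotoxicity (a lower number here means that less compound is tolerated, a higher number that more compound is tolerated), compound 1 gives > 25000 nM, which is a limit of the assay. In this assay compound 2 gives > 25000 nM, also a limit of the assay. The step that the two limits leave unreadable from compound 1 to compound 2 therefore cannot be sized. Compound 2 stands at the limit of > 25000 nM in this assay, at which 2 of the 2 values shown sit, so its tolerance is not pinned to a number.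

Compound 3 `CNC(=S)N/N=C1\C(=O)Nc2ccccc21` differs from compound 2 in one place: methyl in place of 4-bromophenyl on an amide-type nitrogen. Within the data shown here, only one measured step bears on this change, a step that the two limits leave unreadable from compound 1 to compound 2, and its size is not readable. Among the measured compounds shown here, no measured step shows a shift in this assay beyond the scatter. Compound 3 is therefore expected to remain at or beyond the limit, with an expected step that the limit leaves unreadable from compound 2 to compound 3. The estimate for compound 3 in this assay is 40000 nM, ranging from 15000 nM to 120000 nM.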

Compound 3, half-maximal cytotoxic concentration: > 25000 nM
Compound 3: a limit, no number (the forecaster's own chance of this, stated with the estimate: 80%); the middle value does not contradict the limit.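

No step can be read among compound 1, compound 2 and compound 3 in this assay, since each stands at a limit: the limit of > 25000 nM in this assay, at which 3 of the 3 values shown sit. The compounds shown leave open what concentration of any of them is tolerated, and whether the group on the amide-type nitrogen matters at all.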